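Furan swapped for benzofuran at the assay limit

This account rests on a few compounds, and the source may have more. Where it says the series, first, only, none or still open, it means among the compounds named here.

Measured in a functional assay on CEM-DNR-bulk cells (Homo sapiens), read by MTT assay, with a stated time of 72 h; a lower number here means a stronger inhibitor, a higher number a weaker inhibitor:
Compound 1 `CSc1ncnc2c1c(-c1ccoc1)cn2[C@@H]1O[C@H](CO)[C@@H](O)[C@H]1O` gives > 20000 nM as a limit
Compound 2 `CNc1ncnc2c1c(-c1cc3ccccc3o1)cn2[C@@H]1O[C@H](CO)[C@@H](O)[C@H]1O` gives > 20000 nM as a limit
Compound 3 `Cc1ncnc2c1c(-c1ccoc1)cn2[C@@H]1O[C@H](CO)[C@@H](O)[C@H]1O` gives > 20000 nM as a limit

Compound 3 has no number of its own, and its standing is given only by the limit of > 20000 nM in this assay, at which 3 of the 3 values shown sit, as the common result for all three compounds. The change under discussion leads to compound 4 `Cc1ncnc2c1c(-c1cc3ccccc3o1)cn2[C@@H]1O[C@H](CO)[C@@H](O)[C@H]1O` and puts 1-benzofuran-2-yl in place of furan-3-yl on an aromatic carbon, counted as 1-benzofuran-2-yl in place of furan-3-yl on an aromatic carbon with the rest of the structure unchanged.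

Within the data shown here, only one measured step touches compound 3. It is a step that the two limits leave unreadable from compound 1 to compound 3 and it concerns another part of the structure, so it offers no size to carry over. Compound 2 already bears 1-benzofuran-2-yl and gives > 20000 nM as a limit of the assay.

The data therefore supply no measured size for this change, and no step beyond the scatter is expected in this assay in either direction. The expected step is a number no higher from compound 3 to compound 4 (the limit leaves the size open) and no direction is favoured. For compound 4 the estimated value is 20000 nM with an expected range from 9000 nM to 40000 nM and a report as a limit is the likeliest outcome.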

Compound 4, half-maximal inhibitory concentration: > 20000 nM
Compound 4: a limit, no number; the forecaster's own chance of this, stated with the estimate: 85%; the middle value sits exactly at the limit.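

In this assay compound 4 gives > 20000 nM, which is a limit and not a number. The steps to compound 4 from compound 3 and from compound 2 cannot be read, and all the compounds share one result: the limit of > 20000 nM in this assay, at which 4 of the 4 values shown sit. The compounds shown leave open how any of these four compounds' true values compare in this assay.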